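Thiophen-2-yl to Furan-2-yl: What to Expect for Compound 4

The compounds below may be only part of what the source reports. "The series", "measured", "known", "first", "only" and "open" are said of these compounds alone.

Measured compounds, each with its structure and its result in an assay on isolated protein for inhibition of DNA topoisomerase 1 (Homo sapiens), with a stated time of 30 min, tested at 100 uM; a higher number here means a stronger effect of the compound at the concentration tested, a lower number a weaker effect:
- Compound 1, `Oc1cccc(-c2cc(-c3ccc(Cl)cc3)nc(-c3ccco3)c2)c1`, gives 27.1%.
- Compound 2, `Oc1ccc(-c2cc(-c3ccncc3)nc(-c3ccc(Cl)cc3)c2)cc1`, gives 5.9%.
- Compound 3, `Oc1ccc(-c2cc(-c3ccc(Cl)cc3)nc(-c3cccs3)c2)cc1`, gives 38.8%.

Compound 3 shows the highest number of the three. Its nearest neighbour is compound 1, which sits beyond the scatter below it, and compound 2 lies furthest below it, also beyond the scatter.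

The step now followed leads from compound 3 to compound 4, whose structure is `Oc1ccc(-c2cc(-c3ccc(Cl)cc3)nc(-c3ccco3)c2)cc1`. The change is furan-2-yl in place of thiophen-2-yl on an aromatic carbon. For the measured compounds named here, only one measured step is on record, and it concerns a different position of the shared core: a number 32.9 percentage points higher from compound 2 to compound 3 (beyond the scatter). That step does not involve furan-2-yl, so it bears on the present change only indirectly. Compound 1, which carries furan-2-yl but also differs from compound 3 in where the hydroxy group sits on the phenyl ring, gives a lower value than compound 3, so a modest drop is expected, though not with confidence.

For compound 4 the expected value in this assay is 30%, with a likely range from 15% to 45%, which means an expected step of a number 8.8 percentage points lower from compound 3 to compound 4 (within the scatter).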

Compound 4, a percentage reported as inhibition, at one concentration (the size of the read-out at that concentration, not a potency): 15.8%
For compound 4 the middle estimate is 14.2 percentage points above the measured one; the range from low to high includes it.
By their numbers in this assay, from the lowest: compounds 2 and 4 (each within the scatter of the next); then compound 1; then compound 3.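

In this assay, swapping a single ring atom, sulfur for oxygen, in the five-membered aromatic ring next to the ring nitrogen gives a number 23 percentage points lower from compound 3 to compound 4 (beyond the scatter) and shows that furan-2-yl is not interchangeable with thiophen-2-yl at this place, although both groups have the same heavy-atom count. Furan-2-yl also cannot be told apart from pyridin-4-yl, with a number 9.9 percentage points higher from compound 2 to compound 4 (within the scatter) in the same assay, so among these three groups only thiophen-2-yl stands clear of the other two. The position of the hydroxy group matters as well: a number 11.3 percentage points lower from compound 1 to compound 4 (beyond the scatter) isolates this change with furan-2-yl in place, something compound 1 and compound 3 could not do, as they differ in two places. Nothing available here explains why either change moves the number.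

As far as these compounds go, it remains open whether an aminomethyl group or a plain phenyl ring at this place would match thiophen-2-yl. Also open, from the compounds shown here alone, is whether moving the hydroxy group has a similar effect when thiophen-2-yl sits on the core, and, with every number taken at one concentration, how these differences would translate into potency.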